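Removing One Methyl From a Hydroxylated Side Chain

This account rests on a few compounds, and the source may have more. Where it says the series, first, only, none or still open, it means among the compounds named here.

In a functional assay on DU-145 cells (Homo sapiens) for cytotoxicity, read by MTT assay (a higher number here means a weaker inhibitor, a lower number a stronger inhibitor), compound 1 (`COCCO[C@H](CC=C(C)C)C1=CC(=O)c2c(O)ccc(O)c2C1=O`) gives 43200 nM. Compound 2 (`CC[C@](C)(O)CC(=O)O[C@H](CC=C(C)C)C1=CC(=O)c2c(O)ccc(O)c2C1=O`) gives 20500 nM, and compound 3 (`CC(C)=CC[C@@H](OCC(C)O)C1=CC(=O)c2c(O)ccc(O)c2C1=O`) gives 16100 nM. Compound 3 therefore sits level with compound 2 at the low end of this small set, and compound 1 lies clearly higher.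

Compound 4 (`CC(C)=CC[C@@H](OCCO)C1=CC(=O)c2c(O)ccc(O)c2C1=O`) changes compound 3 in one small way: hydrogen in place of methyl on a saturated chain carbon bound to an oxygen on a saturated carbon and a saturated chain carbon. This is hydrogen in place of methyl on a saturated chain carbon, which turns 2-hydroxypropoxy into 2-hydroxyethoxy.

Among the compounds with values here, no measured step removes this methyl alone, so the evidence is indirect. A wider change to the same chain gave a 2.7-fold lower number from compound 1 to compound 3 (0.43 log units; beyond the scatter), which is modest. Replacing the whole group on that oxygen gave a 1.3-fold lower number from compound 2 to compound 3 (0.10 log units; within the scatter). Even these broader changes moved the number little, so a single methyl is not expected to shift it beyond the scatter. The expected change is a 1.1-fold higher number from compound 3 to compound 4 (0.02 log units; within the scatter). For compound 4 the estimated value is 17000 nM, with an expected range of 8500 nM to 34000 nM.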

Compound 4, half-maximal inhibitory concentration: 9900 nM
The estimate for compound 4 lay 1.7-fold (0.23 log units) above the measured number; measured number inside the range.
By their numbers in this assay, from the lowest: compounds 4, 3 and 2 (each within the scatter of the next, the first and the last beyond it); then compound 1.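

In this assay, the change from 2-hydroxypropoxy to 2-hydroxyethoxy gives a 1.6-fold lower number from compound 3 to compound 4 (0.21 log units; within the scatter), so losing this methyl leaves no clear mark on the number. The smaller chain does show something compound 3 could not: its step from the ester side chain, a 2.1-fold lower number from compound 2 to compound 4 (0.32 log units; beyond the scatter), clears the scatter, whereas the step from compound 2 to compound 3 did not, and the step from the methoxy-capped chain, a 4.4-fold lower number from compound 1 to compound 4 (0.64 log units; beyond the scatter), is also beyond it. Nothing available explains why these numbers differ.

Going by these compounds, it remains open how far this chain can change before the number moves clearly, for example with a 3-hydroxypropoxy chain. An amine or a carboxylic acid in place of the end hydroxyl is also an open case.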